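A few compounds are considered here, and "the series" means these few. Any claim that something is new, unique, unknown or untested is made for them only; others in the source may bear on it.

Compound 1 `Cc1ccccc1NC1=C(Nc2ccccc2C)C(=O)c2c(cccc2[N+](=O)[O-])C1=O`: 186000 nM in an ADME assay on L6 cells (Rattus norvegicus) for cytotoxicity, read by sulforhodamine B assay, with a stated time of 72 h; on this read-out higher numbers stand for weaker inhibition and lower numbers for stronger inhibition
Compound 2 `O=C1C(Nc2ccc(C(F)(F)F)cc2)=C(Nc2ccc(C(F)(F)F)cc2)C(=O)c2ccccc21`: 276000 nM in this assay

Compound 2 and compound 1 lie within the scatter of each other in this assay, so the two numbers cannot be told apart. Compound 3 `O=C1C(Nc2ccc(C(F)(F)F)cc2)=C(Nc2ccc(C(F)(F)F)cc2)C(=O)c2c1cccc2[N+](=O)[O-]` differs from compound 2 by nitro in place of hydrogen on an aromatic carbon, a nitro in place of hydrogen on an aromatic carbon. Going by the values given here, no measured pair shows this change, so the data give no step to lean on; compound 1, which also carries a nitro group, offers only a value within the scatter of compound 2. Compound 3 is therefore expected to stay close to compound 2, with an estimated step of a 1.3-fold lower number from compound 2 to compound 3 (0.10 log units; within the scatter) that is not beyond the scatter. The estimate for compound 3 is 220000 nM, with a range from 110000 nM to 440000 nM.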

Compound 3, half-maximal inhibitory concentration: 97000 nM
For compound 3 the middle estimate is 2.3-fold (0.36 log units) above the measured one; the measured number lies below the stated range.
By their numbers in this assay, from the lowest: compounds 3, 1 and 2 (each within the scatter of the next, the first and the last beyond it).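

Nitro in place of hydrogen on this aromatic carbon of the fused ring system gives the first step that can be read in this assay, a 2.8-fold lower number from compound 2 to compound 3 (0.45 log units; beyond the scatter), and the step is modest. It shows that this position is not silent, which compound 1 could not show, since it carries nitro but also differs from compound 2 in other places.

On these data alone, whether an amine or a methoxy group on the same carbon would shift the number in the same direction remains open. So does whether nitro has a similar step on a core bearing other aniline groups, such as that of compound 1. Nothing available explains the step.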